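A methyl group replaces trifluoromethoxy in compound 4

A few compounds are considered here, and "the series" means these few. Any claim that something is new, unique, unknown or untested is made for them only; others in the source may bear on it.

Values measured in an ADME assay on MDCK cells (Canis lupus familiaris) for cytotoxicity (a lower number here means that less compound is tolerated, a higher number that more compound is tolerated), each of them a limit:
- compound 1 `CC(=O)Nc1ccc2oc(-c3ccnc(C(=O)N4CCN(C(c5cccc(F)c5)c5nnn(C)n5)CC4)c3)nc2c1`: > 50000 nM
- compound 2 `CC(=O)Nc1ccc2oc(-c3ccnc(C(=O)N4CCN(C(c5ccc(F)cc5)c5nnn(C)n5)CC4)c3)nc2c1`: > 50000 nM
- compound 3 `CC(=O)Nc1ccc2oc(-c3ccnc(C(=O)N4CCN(C(c5ccc(OC(F)(F)F)cc5)c5nnn(C)n5)CC4)c3)nc2c1`: > 50000 nM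

Compound 3 gives only a limit, > 50000 nM. The whole set shares it: the limit of > 50000 nM in this assay, at which 3 of the 3 values shown sit.

Compound 4 `CC(=O)Nc1ccc2oc(-c3ccnc(C(=O)N4CCN(C(c5ccc(C)cc5)c5nnn(C)n5)CC4)c3)nc2c1` carries methyl in place of trifluoromethoxy on an aromatic carbon, para to a large group: methyl in place of trifluoromethoxy on an aromatic carbon. The closest measured change is a step that the two limits leave unreadable from compound 2 to compound 3. Alongside it stand a step that the two limits leave unreadable from compound 1 to compound 2 and a step that the two limits leave unreadable from compound 1 to compound 3. None of the three has a readable size, so they suggest no direction, and no step beyond the scatter is expected in this assay. The expected step is a number no higher from compound 3 to compound 4 (the limit leaves the size open). For compound 4 the estimated value is 50000 nM, with an expected range from 25000 nM to 100000 nM.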

Compound 4, half-maximal cytotoxic concentration: > 50000 nM
Compound 4: a limit, no number; the forecaster's own chance of this, stated with the estimate: 90%; the middle value sits exactly at the limit.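

In this assay, among the compounds shown here, compound 4 gives only a limit, > 50000 nM, so no step from compound 1, compound 2 or compound 3 to compound 4 can be read. The compounds shown leave open what size, if any, these changes have, and all of them share one ceiling: the limit of > 50000 nM in this assay, at which 4 of the 4 values shown sit.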